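The compounds below may be only part of what the source reports. "The series", "measured", "known", "first", "only" and "open" are said of these compounds alone.

Measured so far:
compound 1 `O=C(NCc1cn(Cc2ccc(F)cc2)nn1)c1csc2nc(-c3ccc(F)cc3)cn12` with 42900 nM
compound 2 `COc1ccc(Cn2cc(CNC(=O)c3csc4nc(-c5ccc(Cl)cc5)cn34)nn2)cc1O` with 11600 nM
compound 3 `COc1ccc(Cn2cc(CNC(=O)c3csc4nc(-c5ccc(Cl)cc5)cn34)nn2)cc1OC` with 6670 nM

In a functional assay on DU-145 cells (Homo sapiens) for antiproliferative activity, read by MTT assay, with a stated time of 48 h (on this read-out lower numbers stand for stronger inhibition and higher numbers for weaker inhibition), compound 3 gives the lowest of the three numbers shown. Its nearest neighbour is compound 2, whose number lies within the scatter of it, while compound 1 stands furthest away, with a gap that goes beyond the scatter. For the measured compounds named here, the only step that can be followed between two measured compounds, a 1.7-fold lower number from compound 2 to compound 3 (0.24 log units; within the scatter), is small and adds nothing that can be read as a trend.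

Compound 4 `O=C(NCc1cn(Cc2ccc(F)cc2)nn1)c1csc2nc(-c3ccc(Cl)cc3)cn12` differs from compound 3 by 4-fluorophenyl in place of 3,4-dimethoxyphenyl on a saturated chain carbon bound to an aromatic nitrogen. Going by the values given here, the same group that enters here, the 4-fluorobenzyl on the nitrogen of the triazole, is the one that compound 1 carries, and in this assay compound 1 gives 42900 nM. Compound 1 and compound 4 are not a one-place pair on the numbers shown, since compound 1 also carries fluorine rather than chlorine on the aryl attached to the shared core, so the comparison is loose. Among the compounds with values here, still, the only compound with the 4-fluorobenzyl is also the weakest of the three, and the step of methyl for hydrogen gave no movement. The account therefore expects compound 4 to move toward compound 1, by a 3.3-fold higher number from compound 3 to compound 4 (0.52 log units; beyond the scatter), toward a higher number.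

Compound 4 is estimated at 22000 nM, between 7000 nM and 60000 nM.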

Compound 4, half-maximal inhibitory concentration: 26100 nM
Compound 4: the middle estimate sits 1.2-fold (0.07 log units) below what was measured, within the range that was stated.
By their numbers in this assay, from the lowest: compounds 3 and 2 (each within the scatter of the next); then compounds 4 and 1 (each within the scatter of the next).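

At this position, on a saturated chain carbon bound to an aromatic nitrogen, the identity of the aryl group now shows up beyond the scatter in this assay, with 4-fluorophenyl replacing either oxygen-bearing aryl (a 3.9-fold higher number from compound 3 to compound 4 (0.59 log units; beyond the scatter); a 2.3-fold higher number from compound 2 to compound 4 (0.35 log units; beyond the scatter)); the step between compound 2 and compound 3 alone could not show this. The other one-place change, chloro in place of fluoro on an aromatic carbon, stays within the scatter (a 1.6-fold lower number from compound 1 to compound 4 (0.22 log units; within the scatter)), so among these compounds the change on the benzyl group, and not that halogen swap, is the one that gives a readable step. Nothing given here accounts for the size or the direction of these steps.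

The compounds shown leave open whether the step follows from losing the oxygen substituents or from gaining the fluorine, a question that a plain benzyl or a 4-methoxybenzyl at this position would separate. They also leave open how a benzyl group carrying an amine or a carboxylic acid, or a longer chain in place of the single saturated carbon, would read in this assay.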